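Shortening a Propyl Chain While Every Value Sits at a Limit

This account rests on a few compounds, and the source may have more. Where it says the series, first, only, none or still open, it means among the compounds named here.

Compound 2 `CCCc1nc(C)c2c(-c3ccccc3)nnc(SC)n12` is one of three close relatives tested in a functional assay for inhibition, with Homo sapiens as the target; a lower number here means a stronger inhibitor, a higher number a weaker inhibitor. In this assay compound 2 gives > 48000 nM, which is a limit of the assay rather than a number. Compound 1 `CCCc1nc(C)c2c(C)nnc(SC)n12` likewise gives only the limit > 48000 nM. Compound 3 `CCCc1nc(C)c2c(-c3ccccc3)nnc(O)n12` also gives only the limit > 48000 nM. Their common position is the limit of > 48000 nM in this assay, at which 3 of the 3 values shown sit. The two measured steps, a step that the two limits leave unreadable from compound 1 to compound 2 and a step that the two limits leave unreadable from compound 2 to compound 3, therefore give no size to compare against. Compound 4 `CCc1nc(C)c2c(-c3ccccc3)nnc(SC)n12` differs from compound 2 by hydrogen in place of methyl on a saturated chain carbon, two bonds along the chain from an aromatic carbon. For the measured compounds named here, no measured step bears on this change, so no movement beyond the scatter is expected. Compound 4 is therefore estimated at 100000 nM, with a range from 30000 nM to 500000 nM. This amounts to an expected step that the limit leaves unreadable from compound 2 to compound 4.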

Compound 4, half-maximal inhibitory concentration: > 48000 nM
Compound 4: only a limit was reported; the forecaster's own chance of this, stated with the estimate: 85%; the middle value lies beyond the limit too.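

No new step can be read between compound 2 and compound 4, as both values are limits rather than numbers: the limit of > 48000 nM in this assay, at which 4 of the 4 values shown sit.

The compounds shown leave open whether going from propyl to ethyl changes inhibition at all.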